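Replacing the pyrrolidin-1-yl group of compound 1

The source may hold more compounds than are shown below. What is called first, only, known or untested is meant among the compounds shown, and "the series" means these compounds.

In a toxicity assay (L6 cells) for inhibition, with Rattus norvegicus as the target, read by resazurin assay, with a stated time of 70 h (a higher number here means a weaker inhibitor, a lower number a stronger inhibitor), compound 1 (`O=C(CN1CCCC1)NCCNc1ccnc2cc(Cl)ccc12`) gives 46400 nM and stands as the weakest of three measured inhibitors, with both others lower by more than the scatter. Compound 2 (`Clc1ccc2c(NCCCN3CCCCCC3)ccnc2c1`) gives 20000 nM and compound 3 (`CN1CCN(CCNc2ccnc3cc(Cl)ccc23)CC1`) gives 16700 nM in the same test. Compound 4 (`CN1CCN(CC(=O)NCCNc2ccnc3cc(Cl)ccc23)CC1`) has not yet been measured. It carries 4-methylpiperazin-1-yl in place of pyrrolidin-1-yl on a saturated chain carbon bound to a carbonyl carbon. Among the measured compounds shown here, no measured pair shows this change alone, so in this assay only a slight move to a lower number is expected. That lean rests on compound 3 (16700 nM), which holds the same 4-methylpiperazin-1-yl group. The step expected is a 1.2-fold lower number from compound 1 to compound 4 (0.09 log units; within the scatter) and stays within the scatter. For compound 4 the estimate is 38000 nM (expected range 18000 nM to 90000 nM).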

Compound 4, half-maximal inhibitory concentration: 38100 nM
The estimate for compound 4 lay 1.0-fold (0.00 log units) below the measured number; low and high end bracket the measured number.
By their numbers in this assay, from the lowest: compounds 3, 2, 4 and 1 (each within the scatter of the next, the first and the last beyond it).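

In this assay, among the compounds shown here, the swap of pyrrolidin-1-yl for 4-methylpiperazin-1-yl on a saturated chain carbon bound to a carbonyl carbon gives a 1.2-fold lower number from compound 1 to compound 4 (0.09 log units; within the scatter) and so provides the first comparison of compounds differing in one place. At this position, a six-membered ring with 2 hetero atoms and a five-membered ring with 1 cannot be told apart by their numbers. No measured evidence bears on the reason for this result. On these data alone, whether a primary amine or a carboxylic acid at this place would separate from compound 1 stays open, as does the effect of a longer chain.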